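Aryl exchange on the shared core: compound 3 outlook

The source may report more compounds than this note shows. Statements on the series, on what has been measured and on what is new or still open speak of the compounds shown alone.

Of the compounds shown here, two have been measured in a functional assay, with a stated time of 20 min; on this read-out lower numbers stand for stronger inhibition and higher numbers for weaker inhibition. Compound 1 `CCOC(=O)c1cnn(-c2nc(-c3ccc(OC)cc3)c(C#N)c(=O)n2C)c1N` gives 59 ug/mL. Compound 2 `CCOC(=O)c1cnn(-c2nc(-c3ccccc3O)c(C#N)c(=O)n2C)c1N` gives 48 ug/mL. Among the numbers shown, compound 2 stands together with compound 1, its nearest neighbour; the step of a 1.2-fold lower number from compound 1 to compound 2 (0.09 log units; within the scatter) does not separate the two.

Compound 3 `CCOC(=O)c1cnn(-c2nc(-c3ccc(N(C)C)cc3)c(C#N)c(=O)n2C)c1N` is not yet measured. It differs from compound 2 in this way: 4-(dimethylamino)phenyl in place of 2-hydroxyphenyl on an aromatic carbon. Among the measured compounds shown here, no measured step covers this exact exchange. For the measured compounds named here, the single step that bears on it, a 1.2-fold lower number from compound 1 to compound 2 (0.09 log units; within the scatter), shows that exchanging one aryl group on the same carbon for another left the number within the scatter. On that basis no step beyond the scatter is expected in this assay for compound 3, in either direction. The number for compound 3 is estimated at 50 ug/mL, with a range from 25 ug/mL to 100 ug/mL. This estimate corresponds to the expected step of a 1.0-fold higher number from compound 2 to compound 3 (0.02 log units; within the scatter).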

Compound 3, half-maximal inhibitory concentration: 98 ug/mL
The estimate for compound 3 lay 2.0-fold (0.29 log units) below the measured number, within the range that was stated.
By their numbers in this assay, from the lowest: compounds 2, 1 and 3 (each within the scatter of the next, the first and the last beyond it).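

In this assay, among the compounds shown here, an aryl exchange on this carbon now gives a first step beyond the scatter (a 2.0-fold higher number from compound 2 to compound 3 (0.31 log units; beyond the scatter)), though a modest one, so the position does not leave the number unchanged for every aryl group. The other new step (a 1.7-fold higher number from compound 1 to compound 3 (0.22 log units; within the scatter)) stays within the scatter, so 4-(dimethylamino)phenyl and 4-methoxyphenyl are not told apart here, and compound 1 lies within the scatter of both compound 2 and compound 3. Nothing available on these compounds accounts for the separation between 2-hydroxyphenyl and 4-(dimethylamino)phenyl.

Open, on these data alone, is whether that separation goes with the hydroxyl group, the dimethylamino group or the place of each on the aryl ring. As far as these compounds go, a 4-hydroxyphenyl or 2-(dimethylamino)phenyl group would bear on this, and the reading for a carboxylic acid on the aryl ring also remains open.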